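Cyclohexyl in Place of the Bicyclic Amine on the Sulfonyl

The source may hold more compounds than are shown below. What is called first, only, known or untested is meant among the compounds shown, and "the series" means these compounds.

Compound 1 `COc1cccc(S(=O)(=O)c2ccc(CN/C(=N\C#N)Nc3ccncc3)cc2)c1`: 55% in an ADME assay (liver) for metabolic stability, with Liver microsome (Homo sapiens) as the target, using microsomes, with a stated time of 30 min, tested at 1 uM; a higher number here means that more of the compound is left, a lower number that less of the compound is left
Compound 2 `N#C/N=C(\NCc1ccc(S(=O)(=O)N2CC3CCC(C2)O3)cc1)Nc1ccncc1`: 60% in this assay

Of these two numbers compound 2 has the higher one, yet the step of a number 5 percentage points higher from compound 1 to compound 2 (within the scatter) falls inside the usual scatter, so the two cannot be placed in order. Compound 3 `N#C/N=C(\NCc1ccc(S(=O)(=O)C2CCCCC2)cc1)Nc1ccncc1` differs from compound 2 in one place: a group of 6 heavy atoms (6 carbon; one six-membered non-aromatic ring of carbon only) in place of a group of 8 heavy atoms (6 carbon, 1 nitrogen, 1 oxygen; one five-membered non-aromatic ring with 1 hetero atom, one six-membered non-aromatic ring with 2 hetero atoms), on a sulfonyl sulfur. Among the compounds with values here, no measured pair contains this exchange; the only step at hand, a number 5 percentage points higher from compound 1 to compound 2 (within the scatter), exchanged a different group at the same sulfonyl sulfur and moved little. Compound 3 is therefore expected to lie close to compound 2, with the expected step of a number 8 percentage points lower from compound 2 to compound 3 (within the scatter) not beyond the scatter. The estimate for compound 3 in this assay is 52%, ranging from 30% to 75%.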

Compound 3, percent of the compound remaining: 56%
Compound 3: the middle estimate sits 4 percentage points below what was measured; the range from low to high includes it.
By their numbers in this assay, from the lowest: compounds 1, 3 and 2 (each within the scatter of the next).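

Cyclohexyl on the sulfonyl sulfur gives, in this assay, a number 4 percentage points lower from compound 2 to compound 3 (within the scatter) and a number 1 percentage points higher from compound 1 to compound 3 (within the scatter). The three compounds therefore cannot be placed in order, and a ring of carbon only, with no hydrogen-bond acceptors, sits in the same range as the two groups with oxygen or nitrogen. No measurement shown offers an explanation for this. Still open, going by these compounds, is whether a much smaller group such as methyl, or a ring carrying a basic amine or a carboxylic acid, would move the number beyond the scatter.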